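Amine substituent change from compound 2 to compound 3

This account rests on a few compounds, and the source may have more. Where it says the series, first, only, none or still open, it means among the compounds named here.

Measured so far:
Compound 1, `CCCNc1cccc(NC(=O)c2ccc(OCCC)cc2)n1`: in an in vitro assay on HEK-tsA201 cells for antagonist activity at Neuronal acetylcholine receptor; alpha3/beta4 (Homo sapiens), read by fluorescence and calcium flux (on this read-out higher numbers stand for weaker inhibition and lower numbers for stronger inhibition), compound 1 gives 12600 nM.
Compound 2, `CCCOc1ccc(C(=O)Nc2cccc(Nc3cccc(F)c3)n2)cc1`: in this assay compound 2 reaches only the limit of the assay, > 100000 nM.

Compound 2 therefore stands at the limit, with no number of its own; it is the one of the two measured values that sits at the limit of > 100000 nM in this assay, at which 1 of the 2 values shown sits. Among the compounds with values here, the single measured step, an at least 7.9-fold higher number from compound 1 to compound 2 (0.89 log units; beyond the scatter), shows that an aryl amine in place of a propyl amine on the shared core weakens inhibition at least modestly.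

Compound 3, `CCCOc1ccc(C(=O)Nc2cccc(N3CCCCC3)n2)cc1`, differs from compound 2 by piperidin-1-yl in place of (3-fluorophenyl)amino on an aromatic carbon. The measured step bears on it only indirectly: it compares an aryl amine with an alkyl amine, and piperidin-1-yl is an alkyl amine, though one with 0 hydrogen-bond donors, whereas the propylamino of compound 1 and the (3-fluorophenyl)amino of compound 2 each carry one. On that basis a step back toward the number of compound 1 is expected, an at least 3.3-fold lower number from compound 2 to compound 3 (0.52 log units; beyond the scatter), with real uncertainty since compound 2 is itself only a limit. Compound 3 is accordingly estimated at 30000 nM, within 8000 nM to 100000 nM.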

Compound 3, half-maximal inhibitory concentration: > 100000 nM
Compound 3: a limit, no number; the forecaster's own chance of this, stated with the estimate: 40%; middle value at least 3.3-fold (0.52 log units) from the limit.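

In this assay compound 3 also reaches only a limit of the assay, > 100000 nM, and with two limits the step from compound 2 cannot be read. The readable step, an at least 7.9-fold higher number from compound 1 to compound 3 (0.89 log units; beyond the scatter), shows that loss of inhibition at this position does not require an aryl amine: piperidin-1-yl, a non-aromatic ring with 0 hydrogen-bond donors, also falls short of the propylamino group on the shared core. Of the three amines shown, only propylamino gives a number, and the other two stand at the same assay limit: the limit of > 100000 nM in this assay, at which 2 of the 3 values shown sit.

The compounds shown cannot separate the ring of piperidin-1-yl from its lack of a hydrogen-bond donor, so an open-chain dipropylamino group or a ring such as pyrrolidin-1-yl would be needed to tell these apart. Also open, as far as these compounds go, is whether a shorter ethylamino group or a longer butylamino chain would give a lower number than compound 1, which so far is the only measured anchor for this position.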